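The source may hold more compounds than are shown below. What is called first, only, known or untested is meant among the compounds shown, and "the series" means these compounds.

Compound 3, whose structure is `Cc1cc(F)ccc1Nc1ncc(C(F)(F)F)c(N2Cc3cccc(N(C)S(C)(=O)=O)c3C2)n1`, sits at the limit of a functional assay on A549 cells (Homo sapiens) for antiproliferative activity, read by spectrophotometry, with a stated time of 2 days; a higher number here means a weaker inhibitor of growth, a lower number a stronger inhibitor of growth: its value there is > 30000 nM, a limit rather than a number. Compound 2, with structure `Cc1cc(C)cc(Nc2ncc(C(F)(F)F)c(N3Cc4cccc(N(C)S(C)(=O)=O)c4C3)n2)c1`, also sits at a limit in this assay, where compound 2 gives > 30000 nM. Compound 1, with structure `COc1cc(Nc2ncc(C(F)(F)F)c(N3Cc4cccc(N(C)S(C)(=O)=O)c4C3)n2)c(OC)cc1Cl`, is the only one of the three with a readable number, and in this assay compound 1 gives 7300 nM. The two steps from it, an at least 4.1-fold higher number from compound 1 to compound 2 (0.61 log units; beyond the scatter) and an at least 4.1-fold higher number from compound 1 to compound 3 (0.61 log units; beyond the scatter), each reach the limit; the step that the two limits leave unreadable from compound 2 to compound 3 cannot be sized because of the limit of > 30000 nM in this assay, at which 2 of the 3 values shown sit.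

Compound 4, whose structure is `COc1cc(Nc2ncc(C(F)(F)F)c(N3Cc4cccc(N(C)S(C)(=O)=O)c4C3)n2)cc(C(F)(F)F)c1`, is to be measured in this assay. Its change from compound 3 is 3-methoxy-5-(trifluoromethyl)phenyl in place of 4-fluoro-2-methylphenyl on a nitrogen on an aromatic ring. Among the compounds with values here, the steps that bear on it show only that leaving the group of compound 1 for a differently decorated phenyl weakened growth inhibition beyond the scatter, with no readable number at the far end. The entering group, like the 3,5-dimethylphenyl of compound 2, carries its two groups in the 3 and 5 positions, and compound 2 sat at the limit. Compound 4 is therefore expected to remain weak, with the estimated step of an at least 1.2-fold lower number from compound 3 to compound 4 (0.07 log units; that floor lies within the scatter) not readable beyond the scatter. The expected value for compound 4 is 25000 nM, within 6000 nM to 60000 nM.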

Compound 4, concentration for 50% growth inhibition: > 30000 nM
Compound 4: no number, only a limit; the forecaster's own chance of this, stated with the estimate: 55%; middle value at least 1.2-fold (0.07 log units) from the limit.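

With 12 heavy atoms and 1 hydrogen-bond acceptor in the entering 3-methoxy-5-(trifluoromethyl)phenyl, against 8 heavy atoms and 0 acceptors in the leaving 4-fluoro-2-methylphenyl, compound 4 shows that a larger group carrying an acceptor on this nitrogen still gives only a limit, not a number, in this assay. The steps to compound 4 from compound 2 and from compound 3 cannot be read, because both ends of each step are limits: the limit of > 30000 nM in this assay, at which 3 of the 4 values shown sit. The one readable step is an at least 4.1-fold higher number from compound 1 to compound 4 (0.61 log units; beyond the scatter), so all three replacements of the 4-chloro-2,5-dimethoxyphenyl group shown here end at the limit, and none of the compounds shown goes against this.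

On these data alone, how far compound 2, compound 3 and compound 4 lie from one another stays unknown, as does which part of the 4-chloro-2,5-dimethoxyphenyl group is tied to the readable number of compound 1. Also open, as far as these compounds go, is whether an amine or a carboxylic acid on this phenyl ring would give a readable number.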